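The source may report more compounds than this note shows. Statements on the series, on what has been measured and on what is new or still open speak of the compounds shown alone.

Compound 1 `COc1cccc(/C=N/c2ccc(OCc3ccccc3)cc2)c1O` is measured in an assay on isolated protein for inhibition of Amine oxidase [flavin-containing] B (Homo sapiens), read by fluorescence and Amplex Red, with stated times of 15 min and 20 min (a higher number here means a weaker inhibitor, a lower number a stronger inhibitor), where compound 1 gives 6500 nM. Among the compounds with values here, its only neighbour, compound 2 `Oc1cccc(/C=N/c2ccc(OCc3ccccc3)cc2)c1O`, gives 6870 nM in this assay; the step of a 1.1-fold higher number from compound 1 to compound 2 (0.02 log units; within the scatter) leaves compound 1 standing level with compound 2. Compound 3 `Oc1ccccc1/C=N/c1ccc(OCc2ccccc2)cc1` differs from compound 1 by hydrogen in place of methoxy on an aromatic carbon. Within the data shown here, the one step known, from compound 1 to compound 2, also changed this part of the molecule and stayed within the scatter, so a step of about a 1.1-fold higher number from compound 1 to compound 3 (0.03 log units; within the scatter) is expected. Compound 3 is therefore estimated at 7000 nM, with a likely range from 3500 nM to 14000 nM.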

Compound 3, half-maximal inhibitory concentration: 25100 nM
For compound 3 the middle estimate is 3.6-fold (0.55 log units) below the measured one, outside the stated range (above it).
By their numbers in this assay, from the lowest: compounds 1 and 2 (each within the scatter of the next); then compound 3.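

On this aromatic carbon, ortho to a hydroxy group, the group present does matter in this assay: hydrogen in place of methoxy gives a 3.9-fold higher number from compound 1 to compound 3 (0.59 log units; beyond the scatter), and hydrogen in place of hydroxy gives a 3.7-fold higher number from compound 2 to compound 3 (0.56 log units; beyond the scatter). Compounds 1 and 2 alone showed only that methoxy and hydroxy read alike here; now each is seen to go with a stronger inhibitor than hydrogen does. No measurement at hand explains this difference.

Still open, as far as these compounds go, is whether an amine, a fluorine or an ethoxy group on this carbon would read like methoxy and hydroxy or like hydrogen.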